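Nitroimidazole-linked oxadiazoles: cytotoxicity on HepG2 cells

A few compounds are considered here, and "the series" means these few. Any claim that something is new, unique, unknown or untested is made for them only; others in the source may bear on it.

Measured so far:
- compound 1 `Cc1ncc([N+](=O)[O-])n1CCSc1nnc(-c2ccccc2N)o1`: 4500 nM
- compound 2 `COc1cc(-c2nnc(SCCn3c([N+](=O)[O-])cnc3C)o2)cc(OC)c1OC`: 14900 nM

Both compounds were tested in a functional assay on HepG2 cells (Homo sapiens) for cytotoxicity, read by MTT assay, with a stated time of 48 h; on this read-out lower numbers stand for stronger inhibition and higher numbers for weaker inhibition. Compound 1 gives the lowest of the two numbers; compound 2 sits at a higher number, and that gap lies beyond the usual scatter. For the measured compounds named here, no step between measured compounds that differ in one place is available, so no measured change can be attributed to any single group.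

Compound 3 `Cc1ncc([N+](=O)[O-])n1CCSc1nnc(-c2cnccc2N)o1` has not been measured. It differs from compound 1 in one place: 4-aminopyridin-3-yl in place of 2-aminophenyl on an aromatic carbon. Going by the values given here, nothing among the measured compounds shows how an exchange of this kind shifts the read-out. The expected step from compound 1 to compound 3 is therefore small, a 1.3-fold higher number from compound 1 to compound 3 (0.12 log units; within the scatter), with no direction beyond the scatter. On this basis compound 3 is estimated at 6000 nM, with a range from 2000 nM to 18000 nM.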

Compound 3, half-maximal inhibitory concentration: 8400 nM
Compound 3: the middle estimate sits 1.4-fold (0.15 log units) below what was measured; measured number inside the range.
By their numbers in this assay, from the lowest: compounds 1, 3 and 2 (each within the scatter of the next, the first and the last beyond it).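

In this assay, the series now has its first step that changes one place only, and it gives a 1.9-fold higher number from compound 1 to compound 3 (0.27 log units; within the scatter). At this carbon of the five-membered aromatic ring, a six-membered aromatic ring with 1 hetero atom can therefore replace one of carbon only, with the amine retained, without a change in the read-out that stands clear of the scatter. No available data bear on the reason for this result.

The compounds shown leave open what the amine on the six-membered ring contributes, which an unsubstituted phenyl or a 2-hydroxyphenyl at the same carbon would test. Also open, on these data alone, is what the nitro group contributes to the read-out, which a nitrile in its place would test.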